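The compounds below may be only part of what the source reports. "The series", "measured", "known", "first", "only" and "open" are said of these compounds alone.

Working notes on the series, read out in a functional assay on HL-60 cells (Homo sapiens) for antiproliferative activity, with a stated time of 72 h; on this read-out lower numbers stand for stronger inhibition and higher numbers for weaker inhibition. Compound 1 (`Cc1cccc(CNc2ncnc3c2ncn3[C@@H]2O[C@H](CO)[C@@H](O)[C@H]2O)c1`) gives 6400 nM, and compound 2 (`COc1ccccc1CNc1ncnc2c1ncn2[C@@H]1O[C@H](CO)[C@@H](O)[C@H]1O`) gives 2300 nM. Among the measured compounds shown here, compound 2 therefore holds the lower of the only two numbers available. For the measured compounds named here, the single measured step is a 2.8-fold lower number from compound 1 to compound 2 (0.44 log units; beyond the scatter), modest but beyond the scatter, with 2-methoxyphenyl in place of 3-methylphenyl on a saturated chain carbon bound to a nitrogen on an aromatic ring.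

Next in line is compound 3 (`COc1cccc(CNc2ncnc3c2ncn3[C@@H]2O[C@H](CO)[C@@H](O)[C@H]2O)c1OC`), which turns 2-methoxyphenyl into 2,3-dimethoxyphenyl. The change is methoxy in place of hydrogen on an aromatic carbon, ortho to a methoxy group and meta to a large group.

Going by the values given here, only a 2.8-fold lower number from compound 1 to compound 2 (0.44 log units; beyond the scatter) bears on this, and it swaps one group for another, so no measured step shows what adding a group to the ring does. A step no larger than that modest one is expected in this assay, with the direction open and no clear move beyond the scatter. The estimate is a 1.3-fold higher number from compound 2 to compound 3 (0.12 log units; within the scatter). For compound 3 the estimated value is 3000 nM, with an expected range of 1000 nM to 9000 nM.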

Compound 3, half-maximal inhibitory concentration: > 166000 nM
Compound 3 gave a limit, no number; the forecaster's own chance of this, stated with the estimate: 8%; middle value at least 55-fold (1.74 log units) from the limit.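

In this assay the reading for compound 3 is a limit and not a number: the limit of > 166000 nM in this assay, at which 1 of the 3 values shown sits.

Methoxy in place of hydrogen on an aromatic carbon, ortho to a methoxy group and meta to a large group, gives an at least 72-fold higher number from compound 2 to compound 3 (1.85 log units; beyond the scatter), a large step at a ring position that the earlier pair did not touch and the first measured step in which a group is added rather than swapped. The 2,3-dimethoxyphenyl ring also stands behind the 3-methylphenyl ring, with an at least 25-fold higher number from compound 1 to compound 3 (1.41 log units; beyond the scatter), so the modest gain seen in a 2.8-fold lower number from compound 1 to compound 2 (0.44 log units; beyond the scatter) does not carry over when the second methoxy enters.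

The compounds shown leave open whether this loss belongs to methoxy in particular or would follow any group on this carbon, such as fluoro, hydroxy or an amine. They also leave open whether a 3-methoxyphenyl ring, without the 2-methoxy group, would read like compound 1 or like compound 3 in this assay.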